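The source may hold more compounds than are shown below. What is called first, only, known or untested is meant among the compounds shown, and "the series" means these compounds.

Compound 1 `CC(C)OC(=O)c1cnc(Oc2ccc3c(c2)B(O)OC3)cn1` gives > 100000 nM
Compound 2 `CC(C)COC(=O)c1cnc(Oc2ccc3c(c2)B(O)OC3)cn1` gives 17600 nM

In an ADME assay on Jurkat cells (Homo sapiens) for cytotoxicity, read by MTT assay, with a stated time of 72 h (a lower number here means a stronger inhibitor, a higher number a weaker inhibitor), compound 1 gives > 100000 nM as a limit of the assay and not a number. Compound 2 gives 17600 nM and holds the only number shown. Compound 3 `CCCCOC(=O)c1cnc(Oc2ccc3c(c2)B(O)OC3)cn1` changes that compound by propyl in place of isopropyl on a saturated chain carbon bound to an oxygen next to a carbonyl group with propyl in place of isopropyl on a saturated chain carbon bound to an oxygen next to a carbonyl group, which reads as isobutyl to butyl. Going by the values given here, only one measured step bears on this, the step of an at least 5.6-fold lower number from compound 1 to compound 2 (0.75 log units; beyond the scatter) with isobutyl in place of isopropyl on an oxygen next to a carbonyl group. That step lies beyond the scatter, but it swapped a different chain, so a change of similar size is not expected here. The expected outcome is a 1.2-fold lower number from compound 2 to compound 3 (0.07 log units; within the scatter) in this assay and thus no step beyond the scatter. Compound 3 is estimated at 15000 nM with 6000 nM to 50000 nM as its expected range.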

Compound 3, half-maximal inhibitory concentration: > 100000 nM
Compound 3 gave a limit, no number (the forecaster's own chance of this, stated with the estimate: 10%); middle value at least 6.6-fold (0.82 log units) from the limit.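

In this assay, isobutyl and butyl carry the same atoms joined differently, yet replacing one with the other gives an at least 5.6-fold higher number from compound 2 to compound 3 (0.75 log units; beyond the scatter). At this place, then, the result depends on how the chain is joined and not only on its atoms, and the step between compound 1 and compound 3 cannot be read. Of the three chains, only the isobutyl of compound 2 gives a number rather than a limit: the limit of > 100000 nM in this assay, at which 2 of the 3 values shown sit.

Going by these compounds, whether a longer chain or an amine at this place would also give a number stays open.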